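Series notes: chloro to amine side chain on the core

The compounds below may be only part of what the source reports. "The series", "measured", "known", "first", "only" and "open" are said of these compounds alone.

Going by the values given here, compound 3 `CCOc1ccc2c(Cl)ccnc2c1` gives 3460 nM in a functional assay on SK-OV-3 cells (Homo sapiens) for cytotoxicity, read by MTT assay, with a stated time of 48 h (a lower number here means a stronger inhibitor, a higher number a weaker inhibitor), the highest of the three numbers so far; its gap to compound 2 `CN(C)CCNc1ccnc2cc(OCc3ccccc3)ccc12` at 2350 nM lies within the scatter, while its gap to compound 1 `CN(C)CCNc1ccnc2cc(OCc3ccc(F)cc3)ccc12` at 890 nM lies beyond it. Among the compounds with values here, the only measured step in the set, a 2.6-fold higher number from compound 1 to compound 2 (0.42 log units; beyond the scatter), concerns a change elsewhere on the shared core and does not touch the position at hand. Compound 4 `CCOc1ccc2c(NCCN(C)C)ccnc2c1` differs from compound 3 by (2-(dimethylamino)ethyl)amino in place of chloro on an aromatic carbon. Within the data shown here, no measured pair tests this exchange directly; the only guide is that compounds 1 and 2, which carry the same (2-(dimethylamino)ethyl)amino group on a core that otherwise differs, sit at numbers comparable to or below that of compound 3. Compound 4 is therefore expected to land near the middle of the set, with a step of a 1.7-fold lower number from compound 3 to compound 4 (0.24 log units; within the scatter) that may not exceed the scatter. The estimate for compound 4 is 2000 nM, within a range of 700 nM to 6000 nM.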

Compound 4, half-maximal inhibitory concentration: 4620 nM
Compound 4: the middle estimate sits 2.3-fold (0.36 log units) below what was measured; measured number inside the range.
By their numbers in this assay, from the lowest: compound 1; then compounds 2, 3 and 4 (each within the scatter of the next).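

In this assay, (2-(dimethylamino)ethyl)amino in place of chloro on this aromatic carbon, opposite the ring nitrogen, gives a 1.3-fold higher number from compound 3 to compound 4 (0.13 log units; within the scatter), so on this core the exchange does not separate the two groups. With the side chain held, methyl in place of phenyl gives a 2.0-fold higher number from compound 2 to compound 4 (0.29 log units; within the scatter), whereas methyl in place of 4-fluorophenyl gives a 5.2-fold higher number from compound 1 to compound 4 (0.72 log units; beyond the scatter), so only the 4-fluorophenyl compound stands apart from compound 4. Nothing at hand accounts for these numbers.

On these data alone, whether chloro and the side chain would also sit within the scatter of each other on the core carrying the 4-fluorophenyl group remains open. Also open, as far as these compounds go, is how a longer chain between the two nitrogens, or a morpholine in place of the terminal dimethylamino group, would read at this position.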